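Methyl in place of methoxy on the central ring

A few compounds are considered here, and "the series" means these few. Any claim that something is new, unique, unknown or untested is made for them only; others in the source may bear on it.

Compound 3 `COc1cc(-c2c(C)nn(C)c2C)ccc1-c1nnc(N(C)Cc2ccc3nccn3c2)o1` gives 2000 nM in an assay on COS-7 cells for inhibition of tyrosine-protein kinase receptor UFO (Homo sapiens), read by ELISA, with a stated time of 1 h (a lower number here means a stronger inhibitor, a higher number a weaker inhibitor), the second highest of the three numbers measured. Compound 1 `Cc1nn(C)c(C)c1-c1ccc(-c2nnc(N(C)Cc3ccc4nccn4c3)o2)cc1`, the unsubstituted parent, gives 3160 nM; the step is a 1.6-fold lower number from compound 1 to compound 3 (0.20 log units; within the scatter). Within the data shown here, compound 2 `Cc1nn(C)c(C)c1-c1ccc(-c2nnc(N(C)Cc3ccc4nccn4c3)o2)c(Cl)c1` gives 794 nM; the step is a 2.5-fold higher number from compound 2 to compound 3 (0.40 log units; beyond the scatter), the only gap to compound 3 that is beyond the scatter.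

Compound 4 `Cc1cc(-c2c(C)nn(C)c2C)ccc1-c1nnc(N(C)Cc2ccc3nccn3c2)o1` differs from compound 3 by methyl in place of methoxy on an aromatic carbon. Among the measured compounds shown here, no measured pair swaps methyl for methoxy, so the bearing steps are those at the same carbon: a 4.0-fold lower number from compound 1 to compound 2 (0.60 log units; beyond the scatter), and a 1.6-fold lower number from compound 1 to compound 3 (0.20 log units; within the scatter). Both substituents at this carbon gave a lower number than hydrogen, the chloro step beyond the scatter and the methoxy step within it. Methyl is expected to fall between those two outcomes, so the step of a 1.5-fold lower number from compound 3 to compound 4 (0.19 log units; within the scatter) is expected to be small and toward a lower number, likely within the scatter. The estimate for compound 4 is 1300 nM, with a range of 500 nM to 3200 nM.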

Compound 4, half-maximal inhibitory concentration: 398 nM
The estimate for compound 4 lay 3.3-fold (0.51 log units) above the measured number; the measured number lies below the stated range.
By their numbers in this assay, from the lowest: compounds 4 and 2 (each within the scatter of the next); then compounds 3 and 1 (each within the scatter of the next).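

At this carbon, ortho to a large group, methyl on the parent gives a 7.9-fold lower number from compound 1 to compound 4 (0.90 log units; beyond the scatter) in this assay, so a small substituent here can carry a step beyond the scatter even though methoxy did not. The choice of substituent matters as much as its presence: methoxy to methyl gives a 5.0-fold lower number from compound 3 to compound 4 (0.70 log units; beyond the scatter), whereas chloro to methyl gives a 2.0-fold lower number from compound 2 to compound 4 (0.30 log units; within the scatter), leaving methyl and chloro unseparated and compound 3 within the scatter of the parent, compound 1. No measurement on hand explains why methoxy parts from methyl and chloro.

As far as these compounds go, whether ethyl, bromo, hydroxy or a dimethylamino group at this carbon would fall with methyl and chloro or with methoxy remains open. Equally open, from the compounds shown here alone, is whether methyl gives a similar step at another carbon of this ring.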